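A few compounds are considered here, and "the series" means these few. Any claim that something is new, unique, unknown or untested is made for them only; others in the source may bear on it.

Working notes on the series. In a functional assay on cells (Homo sapiens) for cytotoxicity, read by MTT assay, with a stated time of 48 h (on this read-out higher numbers stand for weaker inhibition and lower numbers for stronger inhibition), compound 1 (`O=C(CNc1ccccc1)Nc1cc(O)ccc1O`) gives 13000 nM and compound 2 (`CN(CC(=O)Nc1cc(O)ccc1O)C1CCCCC1`) gives 9000 nM so far. These two values lie within the scatter of each other, so the numbers do not separate compound 2 from compound 1. Compound 3 (`O=C(CNC1CCCCC1)Nc1cc(O)ccc1O`) has not yet been measured. It differs from compound 2 at one place: hydrogen in place of methyl on an amine nitrogen. Among the measured compounds shown here, no pair of measured compounds isolates this change, so the data give no direct precedent for its size or direction. In this assay no step beyond the scatter is expected, and neither direction is favoured. This expectation rests on compound 1 at 13000 nM and compound 2 at 9000 nM as two differently substituted members that remain within the scatter of each other. The estimate corresponds to an expected 1.1-fold higher number from compound 2 to compound 3 (0.05 log units; within the scatter) in this read-out. For compound 3 the estimated value is 10000 nM, with an expected range from 4000 nM to 25000 nM in this assay.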

Compound 3, half-maximal inhibitory concentration: 2000 nM
Compound 3: middle estimate off by 5.0-fold (0.70 log units), on the high side; the whole stated range lies above it.
By their numbers in this assay, from the lowest: compound 3; then compounds 2 and 1 (each within the scatter of the next).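

In this assay, hydrogen in place of methyl on the amine nitrogen gives a 4.5-fold lower number from compound 2 to compound 3 (0.65 log units; beyond the scatter), the first single change in the series shown to move the number beyond the scatter. Cyclohexyl in place of phenyl on an amine nitrogen gives a 6.5-fold lower number from compound 1 to compound 3 (0.81 log units; beyond the scatter), so the group on this nitrogen also matters when the nitrogen keeps its hydrogen; compound 1 and compound 2 differ in both features and stand within the scatter of each other, so that pair could show neither effect alone. No measurement in hand accounts for either step.

The compounds shown leave open whether hydrogen in place of methyl has a similar effect when phenyl rather than cyclohexyl sits on the nitrogen, since only the cyclohexyl pair isolates this change. They also leave open how far the nitrogen tolerates other groups, such as ethyl in place of the methyl of compound 2 or cyclopentyl or benzyl in place of the cyclohexyl of compound 3, and whether any such group on the shared core would give a lower number in this read-out.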